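The compounds below may be only part of what the source reports. "The series", "measured", "known", "first", "only" and "open" are said of these compounds alone.

In a functional assay on CCRF-CEM cells (Homo sapiens) for cytotoxicity, in the presence of a further agent that is not named here (a lower number here means a stronger inhibitor, a higher number a weaker inhibitor), compound 1 `Nc1nc(N)c(CCCN(Cc2ccc(NC(CCC(=O)O)C(=O)O)cc2)c2ccc([N+](=O)[O-])c(F)c2F)c(O)n1` reaches only the limit of the measurement, > 100000 nM. Compound 2 `Nc1nc(N)c(CCCN(Cc2ccc(NC(CCC(=O)O)C(=O)O)cc2)c2cc(F)ccc2[N+](=O)[O-])c(O)n1` likewise gives only a limit, > 100000 nM, in this assay. The step that the two limits leave unreadable from compound 2 to compound 1 arises from 2,3-difluoro-4-nitrophenyl in place of 5-fluoro-2-nitrophenyl on an amine nitrogen, and its size stays hidden owing to the limit of > 100000 nM in this assay, at which 2 of the 3 values shown sit. For the measured compounds named here, compound 3 `CC(C)(C)OC(=O)CCC(Nc1ccc(CN(CCCc2c(N)nc(N)nc2O)c2cc(F)ccc2[N+](=O)[O-])cc1)C(=O)OC(C)(C)C` differs from compound 2 by a larger part of the molecule, a difference that is not broken down here; in this assay compound 3 gives 14000 nM, the only number among the three. Compound 4 `CC(C)(C)OC(=O)CCC(Nc1ccc(CN(CCCc2c(N)nc(N)nc2O)c2ccc([N+](=O)[O-])c(F)c2F)cc1)C(=O)OC(C)(C)C` stands to compound 3 as compound 1 stands to compound 2, through (2,3-difluoro-4-nitrophenyl in place of 5-fluoro-2-nitrophenyl on an amine nitrogen), the same change at the same place. Since the earlier step has no readable size, the expected step of a 1.4-fold higher number from compound 3 to compound 4 (0.15 log units; within the scatter) is taken as small, with wide uncertainty. For compound 4 in this assay the estimate is 20000 nM, expected to fall between 4000 nM and 100000 nM.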

Compound 4, half-maximal inhibitory concentration: 20000 nM
Compound 4: the middle estimate sits on the measured number at the digits printed; the measured number falls inside the stated range.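

In this assay, the change to 2,3-difluoro-4-nitrophenyl from 5-fluoro-2-nitrophenyl on the core of compound 3 gives a 1.4-fold higher number from compound 3 to compound 4 (0.15 log units; within the scatter), so on this core the two groups cannot be told apart. For the compounds shown here, the same change on the core of compound 2 cannot be read, because compound 2 and compound 1 both give only a limit of the assay: the limit of > 100000 nM in this assay, at which 2 of the 4 values shown sit. Carrying the change from one core to the other therefore remains untested, as only one core gives a readable step.

The compounds shown leave open how an amine in place of the nitro group, or a longer chain on the amine nitrogen, would read in this assay. Also open, going by these compounds, is which part of the larger difference between compound 2 and compound 3 matters.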